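The source may report more compounds than this note shows. Statements on the series, on what has been measured and on what is new or still open speak of the compounds shown alone.

Compound 2 `Cc1cc(NC(=O)CC(=O)O)c2c(c1Oc1ccc(O)c(CCc3ccccc3Cl)c1)CCC2` gives 30 nM in an in vitro assay on cells for displacement of a labelled ligand from thyroid hormone receptor beta (Homo sapiens), with a stated time of 48 h (on this read-out lower numbers stand for stronger inhibition and higher numbers for weaker inhibition), the highest of the two numbers measured; compound 1 `Cc1cc(NC(=O)CC(=O)O)c2c(c1Oc1ccc(O)c(CCc3ccc(F)cc3)c1)CCC2` gives 8.2 nM in this assay. For the measured compounds named here, the single measured step, a 3.7-fold higher number from compound 1 to compound 2 (0.56 log units; beyond the scatter), concerns a different exchange and does not involve the 3-chlorophenyl group. Compound 3 `Cc1cc(NC(=O)CC(=O)O)c2c(c1Oc1ccc(O)c(CCc3cccc(Cl)c3)c1)CCC2` differs from compound 2 by 3-chlorophenyl in place of 2-chlorophenyl on a saturated chain carbon, two bonds along the chain from an aromatic carbon. Going by the values given here, with no measured step bearing directly on this change, compound 3 is expected to give a number in this assay close to compound 2, within the scatter or modestly lower, an estimated 1.5-fold lower number from compound 2 to compound 3 (0.18 log units; within the scatter). Compound 3 is therefore estimated at 20 nM, between 7 nM and 60 nM.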

Compound 3, inhibition constant: 41 nM
Compound 3: middle estimate off by 2.1-fold (0.31 log units), on the low side, within the range that was stated.
By their numbers in this assay, from the lowest: compound 1; then compounds 2 and 3 (each within the scatter of the next).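

In this assay, 3-chlorophenyl in place of 2-chlorophenyl on this saturated chain carbon gives a 1.4-fold higher number from compound 2 to compound 3 (0.14 log units; within the scatter), so the two chlorophenyl compounds cannot be told apart. Compound 3, like compound 2, stays clearly separated from the 4-fluorophenyl compound, with a 5.0-fold higher number from compound 1 to compound 3 (0.70 log units; beyond the scatter). No evidence is available to explain these results. Still open, as far as these compounds go, is how 4-chlorophenyl would compare with 4-fluorophenyl, which would separate the identity of the halogen from where it sits on the ring. Also open, from the compounds shown here alone, is how an unsubstituted phenyl or a longer chain would read here.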